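Adding a butoxy group to a weakly active sulfonamide

This account rests on a few compounds, and the source may have more. Where it says the series, first, only, none or still open, it means among the compounds named here.

Compound 1 `CN(C)S(=O)(=O)c1ccc(Nc2ccc(C(=O)c3c(F)cccc3F)c(N)n2)cc1` reaches only a limit in a functional assay on HeLa cells (Homo sapiens) for antiproliferative activity (on this read-out lower numbers stand for stronger inhibition and higher numbers for weaker inhibition), namely > 10000 nM.
Compound 2 `Nc1nc(Nc2ccc(S(N)(=O)=O)cc2)ccc1C(=O)c1c(F)cccc1F` gives 17200 nM in this assay.

Compound 2 thus holds the only number shown; the other result is a limit. Compound 3 `CCCCOc1cc(Nc2ccc(S(N)(=O)=O)cc2)nc(N)c1C(=O)c1c(F)cccc1F` differs from compound 2 by butoxy in place of hydrogen on an aromatic carbon. Among the measured compounds shown here, the single measured step, a step that the limit leaves unreadable from compound 1 to compound 2, concerns the sulfonyl substituent rather than this position, and its size cannot be read because of the limit of > 10000 nM in this assay, at which 1 of the 2 values shown sits. For the measured compounds named here, no measured step therefore bears on the butoxy change, so no shift beyond the scatter is expected. Compound 3 is estimated at 15000 nM, in the range 3000 nM to 60000 nM. That estimate means a 1.1-fold lower number from compound 2 to compound 3 (0.06 log units; within the scatter).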

Compound 3, half-maximal inhibitory concentration: 10700 nM
Estimate against measurement, compound 3: 1.4-fold (0.15 log units) above; the measured number falls inside the stated range.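

Butoxy in place of hydrogen on the aromatic carbon opposite the ring nitrogen gives a 1.6-fold lower number from compound 2 to compound 3 (0.21 log units; within the scatter) in this assay. Among the compounds shown here, the earlier compounds differed only at the sulfonyl sulfur, so this is the first reading at this position, and it shows that this position can carry a butoxy chain with no change in the read-out beyond the scatter. Nothing measured here bears on the cause of this result.
On these data alone, whether methoxy, a longer chain, an amine or a carboxylic acid on this carbon would move the number beyond the scatter remains open.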